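This account rests on a few compounds, and the source may have more. Where it says the series, first, only, none or still open, it means among the compounds named here.

Working notes on the thiosemicarbazone series in a functional assay on HT-29 cells (Homo sapiens) for cytotoxicity, read by sulforhodamine B assay; a higher number here means that more compound is tolerated, a lower number that less compound is tolerated.

Compound 1 `CC1=CC[C@@H]([C@@](C)(O)CCCC(C)(C)NC(=S)NN)CC1` is the parent hydrazide of the series. In this assay compound 1 gives only a limit, > 100000 nM, and no number. Compound 2 `COc1ccc(/C=N\NC(=S)NC(C)(C)CCC[C@](C)(O)[C@@H]2CC=C(C)CC2)cc1` carries the 4-methoxyphenyl aldimine on the terminal nitrogen. In this assay compound 2 likewise stops at a limit, > 100000 nM. Compound 3 `CC1=CC[C@@H]([C@@](C)(O)CCCC(C)(C)NC(=S)N/N=C\c2ccc([N+](=O)[O-])cc2)CC1` is the nitro analogue. In this assay compound 3 also returns a limit, > 100000 nM.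

The two measured steps are therefore not readable: a step that the two limits leave unreadable from compound 1 to compound 2 and a step that the two limits leave unreadable from compound 2 to compound 3. The only firm point is the limit of > 100000 nM in this assay, at which 3 of the 3 values shown sit; no step size can be taken from the set.

Compound 4 `CC1=CC[C@@H]([C@@](C)(O)CCCC(C)(C)NC(=S)N/N=C\c2ccccc2Cl)CC1` differs from compound 2 by 2-chlorophenyl in place of 4-methoxyphenyl on a carbon with a double bond to nitrogen. For the measured compounds named here, no measured step bears on an aromatic substituent of this kind, and both steps touching compound 2 are unreadable. Compound 4 is expected to remain at the limit, with an estimated step that the limit leaves unreadable from compound 2 to compound 4. The estimate for compound 4 is 150000 nM, within 50000 nM to 500000 nM.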

Compound 4, concentration lethal to 50% of the cells: > 100000 nM
Compound 4 was reported as a limit (the forecaster's own chance of this, stated with the estimate: 80%); the middle value is on the limit's open side.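

In this assay compound 4 gives > 100000 nM, again a limit and not a number. For the compounds shown here, no step joining compound 4 to compound 1, compound 2 or compound 3 can be read: the limit of > 100000 nM in this assay, at which 4 of the 4 values shown sit. The compounds shown leave open whether any group on the terminal nitrogen changes the read-out at all.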